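Aryl piperazine variation on the oxazole series

The compounds below may be only part of what the source reports. "The series", "measured", "known", "first", "only" and "open" are said of these compounds alone.

Measured compounds:
- compound 1 `CCCc1nc(-c2ccccc2)c(CNCCCN2CCN(c3cccc(C(F)(F)F)c3)CC2)o1`: 650 nM
- compound 2 `CCCc1nc(-c2ccccc2)c(CNCCN2CCN(c3ccc(OC)cc3)CC2)o1`: 9200 nM

In an assay on HEK293 cells for inhibition of Voltage-dependent T-type calcium channel subunit alpha-1G (Homo sapiens), read by patch clamp (on this read-out lower numbers stand for stronger inhibition and higher numbers for weaker inhibition), compound 1 gives 650 nM, the lowest of the two numbers in hand. Compound 2 gives 9200 nM, a far higher number, beyond the scatter of repeat runs. Compound 2 differs from compound 1 in more than one place, so no single-point step can be read from the pair; the two values only show that the series is sensitive to changes at this end of the molecule.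

Compound 3 `CCCc1nc(-c2ccccc2)c(CNCCCN2CCN(c3ccc(C)cc3)CC2)o1` is still to be tested. It is made from compound 1 by one change: 4-methylphenyl in place of 3-(trifluoromethyl)phenyl on an amine nitrogen in a ring. Given that compound 2 shows the weaker number in this assay with a different aryl group on the same ring nitrogen, a move toward weaker inhibition is expected for compound 3, though of uncertain size. The step of a 3.1-fold higher number from compound 1 to compound 3 (0.49 log units; beyond the scatter) is the estimated outcome. Compound 3 is expected to give about 2000 nM in this assay, within 600 nM to 7000 nM.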

Compound 3, half-maximal inhibitory concentration: 130000 nM
Estimate against measurement, compound 3: 65-fold (1.81 log units) below, and the stated range ends below it.
By their numbers in this assay, from the lowest: compound 1; then compound 2; then compound 3.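

Among these compounds, this is the first single-point read on the aryl group: in this assay, 4-methylphenyl in place of 3-(trifluoromethyl)phenyl on the ring nitrogen gives a 200-fold higher number from compound 1 to compound 3 (2.30 log units; beyond the scatter), a large move toward weaker inhibition and beyond the scatter. With the rest of compound 1 unchanged, the inhibition in this pair depends strongly on the aryl group at this position, and a phenyl ring alone on that nitrogen does not secure it. Nothing available accounts for the size of this step.

The change alters both the substituent and its place on the phenyl ring, so the pair cannot say which of the two matters. Compounds carrying 3-methylphenyl or 4-(trifluoromethyl)phenyl on the same nitrogen would separate them, and a chlorine or a nitrile on the phenyl ring would test how specific the trifluoromethyl group is.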